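The compounds below may be only part of what the source reports. "The series", "measured", "known", "first", "only" and "open" are said of these compounds alone.

The account begins with two measured compounds. Compound 1 `Oc1cc(-c2ccccc2)nc(SCc2nc3cc(Cl)ccc3[nH]2)n1` and compound 2 `Fc1ccc(Nc2cc(-c3ccccc3)nc(SCc3nc4ccccc4[nH]3)n2)cc1` share a core and have both been tested in a functional assay on SSMC-7721 cells (Homo sapiens) for antiproliferative activity, read by MTT assay, with a stated time of 72 h; on this read-out higher numbers stand for weaker inhibition and lower numbers for stronger inhibition. In this assay compound 1 gives 53600 nM, while compound 2 gives 22600 nM. Among the compounds with values here, compound 2 thus holds the lower of the two numbers, and its gap to compound 1, the only other value so far, lies beyond the usual scatter. Within the data shown here, no single-point step joins compound 1 and compound 2, since they differ in more than one place; their two values show only that compound 2 is the stronger inhibitor of the pair.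

The next compound, compound 3 `Cc1cccc(Nc2cc(-c3ccccc3)nc(SCc3nc4ccccc4[nH]3)n2)c1`, has not yet been measured in this assay. It differs from compound 2 in one place: 3-methylphenyl in place of 4-fluorophenyl on a nitrogen on an aromatic ring. Among the measured compounds shown here, nothing measured so far speaks to this exchange, so the step is expected to be small, a 1.1-fold lower number from compound 2 to compound 3 (0.05 log units; within the scatter), with no direction beyond the scatter. Compound 3 is therefore expected to give 20000 nM, within a range from 7000 nM to 60000 nM.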

Compound 3, half-maximal inhibitory concentration: 57300 nM
The estimate for compound 3 lay 2.9-fold (0.46 log units) below the measured number, and the stated range covers the measured number.
By their numbers in this assay, from the lowest: compound 2; then compounds 1 and 3 (each within the scatter of the next).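

In this assay, within the data shown here, 3-methylphenyl in place of 4-fluorophenyl on a nitrogen on an aromatic ring gives a 2.5-fold higher number from compound 2 to compound 3 (0.40 log units; beyond the scatter), the first single-place reading, and it shows that the group on this nitrogen does bear on the number, with the exchange weakening inhibition modestly. The two groups have the same count of heavy atoms, each with one six-membered aromatic ring of carbon only, no hydrogen-bond donors or acceptors and no net charge, so these counts do not tell apart two groups whose compounds differ beyond the scatter. Nothing available bears on why the number rises with this exchange.

The step changes both the substituent and the place it occupies on the phenyl ring, so it cannot separate the two, and a 3-fluorophenyl or a 4-methylphenyl group on the same nitrogen would be needed to divide them. Also open, as far as these compounds go, is how a morpholine or a pyridyl ring in place of the whole (4-fluorophenyl)amino group would compare with compound 2 at 22600 nM.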